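Exchanging an ester for fluorine on the shared core

The compounds below may be only part of what the source reports. "The series", "measured", "known", "first", "only" and "open" are said of these compounds alone.

Compound 1 `CCOc1ccc2oc(/C=C/[S+](C)[O-])cc(=O)c2c1`: 1500 nM
Compound 2 `CC(C)C(=O)Oc1ccc2oc(/C=C/[S+](C)[O-])cc(=O)c2c1`: 2400 nM
Compound 3 `CCC(=O)Oc1ccc2oc(/C=C/[S+](C)[O-])cc(=O)c2c1`: 2400 nM

All three were tested in a functional assay on A549 cells (Homo sapiens) for cytotoxicity, with a stated time of 48 h; on this read-out lower numbers stand for stronger inhibition and higher numbers for weaker inhibition. Compound 3 stands level with compound 2 at the digits given, the two together the highest of the three numbers, while a 1.6-fold higher number from compound 1 to compound 3 (0.20 log units; within the scatter). Compound 4 `C[S+]([O-])/C=C/c1cc(=O)c2cc(F)ccc2o1` is not yet measured; it differs from compound 3 by fluoro in place of propanoyloxy on an aromatic carbon. The known steps, a 1.6-fold higher number from compound 1 to compound 2 (0.20 log units; within the scatter), a 1.6-fold higher number from compound 1 to compound 3 (0.20 log units; within the scatter) and no change at the digits printed from compound 2 to compound 3 (within the scatter), all vary what sits on the oxygen on the aromatic ring and none moved beyond the scatter. Among the measured compounds shown here, no step removes that oxygen, so none bears directly on this change. The expected step is therefore small: a 1.2-fold lower number from compound 3 to compound 4 (0.08 log units; within the scatter). Compound 4 is estimated at 2000 nM, in a range from 600 nM to 7000 nM.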

Compound 4, half-maximal inhibitory concentration: 2100 nM
The estimate for compound 4 lay 1.1-fold (0.02 log units) below the measured number, within the range that was stated.
By their numbers in this assay, from the lowest: compounds 1, 4, 2 and 3 (each within the scatter of the next).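

In this assay, fluoro on this aromatic carbon gives numbers within the scatter of all three oxygen-linked compounds (a 1.1-fold lower number from compound 3 to compound 4 (0.06 log units; within the scatter); a 1.1-fold lower number from compound 2 to compound 4 (0.06 log units; within the scatter); a 1.4-fold higher number from compound 1 to compound 4 (0.15 log units; within the scatter)). The earlier compounds shown here varied only what sits on the oxygen, whereas this change removes that oxygen and replaces five heavy atoms with one, still without a step beyond the scatter. Nothing available explains this result.

Going by these compounds, whether an amine, a carboxylic acid or a longer chain at this place would also stay within the scatter remains open. So does whether fluoro behaves the same way in other cell lines.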